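This account rests on a few compounds, and the source may have more. Where it says the series, first, only, none or still open, it means among the compounds named here.

Measured so far:
compound 1 `Cn1cc(-c2cnc3ccc(NCC4CC4)nc3c2)cn1`: > 50000 nM
compound 2 `CC(=O)Nc1nccc2ncc(-c3cnn(C)c3)cc12`: > 50000 nM

Both compounds share one core carrying a methylpyrazole, and both have been tested in a functional assay on HeLa cells (Homo sapiens) for antiproliferative activity, read by MTT assay, with a stated time of 48 h; a lower number here means a stronger inhibitor, a higher number a weaker inhibitor. For compound 1 the result is only a limit of the assay, > 50000 nM. For compound 2 the result is likewise a limit and not a number, > 50000 nM. Among the compounds with values here, compound 2 thus stands at the limit, and so does the one other value shown: the whole set sits there (the limit of > 50000 nM in this assay, at which 2 of the 2 values shown sit). Within the data shown here, nothing measured so far separates the two compounds or tells how potency moves with any change on this core.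

Compound 3 `Cn1cc(-c2cnc3ccnc(NC(=O)c4ccc(F)cc4)c3c2)cn1` differs from compound 2 in one place: 4-fluorophenyl in place of methyl on a carbonyl carbon. Among the measured compounds shown here, no measured step shows what this change does here, and the only anchor, compound 2, is a limit. A modest gain in potency in this assay is expected, without a firm basis, and the outcome may again be reported only as a limit. The expected step is an at least 1.4-fold lower number from compound 2 to compound 3 (0.15 log units; that floor lies within the scatter). Compound 3 is estimated at 35000 nM, between 6000 nM and 100000 nM.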

Compound 3, half-maximal inhibitory concentration: > 50000 nM
Compound 3: a limit, no number (the forecaster's own chance of this, stated with the estimate: 60%); at least 1.4-fold (0.15 log units) between middle value and limit.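

In this assay compound 3 gives > 50000 nM, a limit and not a number. Compound 2 is also only a limit, so no step can be read between compound 2 and compound 3. The compounds shown leave open how potency moves with any change on the shared core, and the whole set stands at one value: the limit of > 50000 nM in this assay, at which 3 of the 3 values shown sit.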